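A few compounds are considered here, and "the series" means these few. Any claim that something is new, unique, unknown or untested is made for them only; others in the source may bear on it.

Measured so far in a functional assay on PC-3 cells (Homo sapiens) for antiproliferative activity, read by MTT assay, with a stated time of 48 h; a lower number here means a stronger inhibitor, a higher number a weaker inhibitor:
compound 1 `COc1cc(-c2nnc(SCC(=O)c3ccc(C(F)(F)F)cc3)n2N)cc(OC)c1OC`: > 100000 nM
compound 2 `COc1cc(-c2nnc(SCC(=O)c3cccc(Br)c3)n2N)cc(OC)c1OC`: > 100000 nM
compound 3 `COc1cc(-c2nnc(SCC(=O)Nc3ccccc3)n2N)cc(OC)c1OC`: 37900 nM

The value of compound 1 is a limit of this assay, not a number. The value of compound 2 is likewise a limit (the limit of > 100000 nM in this assay, at which 2 of the 3 values shown sit). Among the compounds with values here, compound 3 therefore holds the only number in the set. The steps of an at least 2.6-fold lower number from compound 1 to compound 3 (0.42 log units; beyond the scatter) and an at least 2.6-fold lower number from compound 2 to compound 3 (0.42 log units; beyond the scatter) are at least modest; the step that the two limits leave unreadable from compound 1 to compound 2 is not readable. Compound 4 `COc1cc(-c2nnc(SCC(=O)NCc3ccc(Cl)cc3)n2N)cc(OC)c1OC` differs from compound 3 by 4-chlorobenzyl in place of phenyl on an amide-type nitrogen. Within the data shown here, no measured step touches this amide-type nitrogen, so no direction can be read from the series. The step from compound 3 to compound 4 is expected to be a 1.1-fold lower number from compound 3 to compound 4 (0.03 log units; within the scatter), within the scatter. Compound 4 is expected to give 35000 nM in this assay, between 9000 nM and 100000 nM.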

Compound 4, half-maximal inhibitory concentration: > 100000 nM
Compound 4: only a limit was reported (the forecaster's own chance of this, stated with the estimate: 30%); middle value at least 2.8-fold (0.45 log units) away from the limit.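

On the amide-type nitrogen, 4-chlorobenzyl in place of phenyl gives an at least 2.6-fold higher number from compound 3 to compound 4 (0.42 log units; beyond the scatter) in this assay, the first change read at this nitrogen, and it goes towards weaker inhibition. The value of compound 4 is a limit and not a number, which leaves a single number in the set: the limit of > 100000 nM in this assay, at which 3 of the 4 values shown sit. The steps joining compound 4 to compound 1 and compound 2 link two limits and cannot be read.

Open, as far as these compounds go, is whether the chlorine or the added carbon of the benzyl group goes with this step. A plain benzyl or a 4-chlorophenyl group on this nitrogen would separate the two.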